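The source may hold more compounds than are shown below. What is called first, only, known or untested is meant among the compounds shown, and "the series" means these compounds.

Measured in a functional assay on MCF7 cells (Homo sapiens) for inhibition, read by MTT assay, with a stated time of 72 h; a higher number here means a weaker inhibitor, a lower number a stronger inhibitor:

Compound 1 `COc1cc(OC)c(OC)cc1/C=C/C(=O)c1ccccc1` gives > 150000 nM as a limit of the assay
Compound 2 `COc1cc(OC)c(OC)cc1/C=C/C(=O)c1ccc(F)cc1` gives 30000 nM as a number
Compound 3 `COc1cc(OC)c(OC)cc1/C=C/C(=O)c1ccc(O)cc1` gives 182000 nM as a number

Compound 3 at 182000 nM holds the higher of the two actual numbers in this assay and its nearest neighbour is compound 2. The entry for compound 1 is a limit. Compound 4 `COc1cc(OC)c(OC)cc1/C=C/C(=O)c1ccc([N+](=O)[O-])cc1` is not yet measured. It carries nitro in place of hydroxy on an aromatic carbon, para to a large group (nitro in place of hydroxy on an aromatic carbon). Among the measured compounds shown here, no step to nitro has been measured, so only the other replacements on that carbon can guide the expectation. There is an at least 5.0-fold lower number from compound 1 to compound 2 (0.69 log units; beyond the scatter) on adding fluoro and a 6.1-fold higher number from compound 2 to compound 3 (0.78 log units; beyond the scatter) on replacing it with hydroxy, while the hydroxy change from hydrogen shows a step that the limit leaves unreadable from compound 1 to compound 3 and gives no size. For the measured compounds named here, compound 2 at 30000 nM is thus the only evidence that a replacement can give a clearly lower number than compound 3, and it is a single case. A modest move to a lower number is expected, with a 4.0-fold lower number from compound 3 to compound 4 (0.61 log units; beyond the scatter) as the estimated step. For compound 4 the estimate is 45000 nM with an expected range from 12000 nM to 170000 nM in this measurement.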

Compound 4, half-maximal inhibitory concentration: > 150000 nM
Compound 4: only a limit was reported; the forecaster's own chance of this, stated with the estimate: 15%; at least 3.3-fold (0.52 log units) between middle value and limit.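

In this assay compound 4 gives > 150000 nM as a limit of the assay, not a number. Set against fluoro, nitro on this aromatic carbon, para to a large group, gives an at least 5.0-fold higher number from compound 2 to compound 4 (0.69 log units; beyond the scatter) and so does not share the lower number of compound 2, which remains the only compound shown with a clearly lower number, and the change at this position does not lower the number by itself. The steps to compound 4 from compound 3 and from compound 1 cannot be read, because a limit stands in each of them: the limit of > 150000 nM in this assay, at which 2 of the 4 values shown sit.

Still open, on these data alone, is whether the lower number of compound 2 belongs to fluoro alone or would also appear with chloro, an amine or a carboxylic acid on the same carbon. Also open, as far as these compounds go, is how compound 4 truly stands against compound 3.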